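The source may hold more compounds than are shown below. What is called first, only, known or untested is meant among the compounds shown, and "the series" means these compounds.

Compound 1 `O=C1NC(c2ccc(Br)cc2)CN1S(=O)(=O)c1ccc2c(c1)CCC2`, giving 33900 nM in a functional assay on A549 cells (Homo sapiens) for cytotoxicity; on this read-out lower numbers stand for stronger inhibition and higher numbers for weaker inhibition.
Compound 2 `Cc1ccc(C2CNC(=O)N2S(=O)(=O)c2ccc(Cl)cc2)cc1`, giving 266000 nM.
Compound 3 `Cc1ccc(S(=O)(=O)N2C(=O)NCC2c2ccccc2)cc1`, giving > 316000 nM, which is a limit of the assay and not a number.

Of the two numbers in hand, compound 1 has the lowest; compound 2 stands at a higher number, a gap beyond the usual scatter. Compound 3 reaches only a limit, one at which one of the three values sits (the limit of > 316000 nM in this assay, at which 1 of the 3 values shown sits). Compound 4 `O=C1NC(c2ccc(Cl)cc2)CN1S(=O)(=O)c1ccc2c(c1)CCC2` has not yet been measured. It differs from compound 1 by chloro in place of bromo on an aromatic carbon. Among the compounds with values here, no measured pair shows this exchange, so the step in this assay is open; a small shift is expected, near the scatter, if anything toward a weaker number. Compound 4 is estimated at 45000 nM, between 15000 nM and 150000 nM. The step of a 1.3-fold higher number from compound 1 to compound 4 (0.12 log units; within the scatter) is therefore expected to be modest.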

Compound 4, half-maximal inhibitory concentration: 86300 nM
For compound 4 the middle estimate is 1.9-fold (0.28 log units) below the measured one, within the range that was stated.
By their numbers in this assay, from the lowest: compound 1; then compound 4; then compound 2. At a limit, above all of these: compound 3.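

With the shared core held fixed, chloro in place of bromo on the aromatic carbon para to a large group gives a 2.5-fold higher number from compound 1 to compound 4 (0.41 log units; beyond the scatter) in this assay, so a single halogen exchange at this position moves the read-out beyond the scatter. Within the data shown here, this is the first one-place comparison, and the step is modest. Nothing measured here bears on the reason for this change. Going by these compounds, whether fluoro, methoxy or an amine at this position would give a lower or higher number remains open, as does whether the same exchange would behave alike with a different group on the sulfonyl.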